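From compound 2 to compound 3: adding methoxycarbonyl

The compounds below may be only part of what the source reports. "The series", "measured", "known", "first", "only" and "open" are said of these compounds alone.

Measured in a functional assay on A549 cells (Homo sapiens) for cytotoxicity, read by MTT assay, with a stated time of 68 h; a lower number here means a stronger inhibitor, a higher number a weaker inhibitor:
- compound 1 `O=C(Nc1cccc(-c2ccc(C(F)(F)F)cc2)c1)C(Cl)Cl`: 23500 nM
- compound 2 `O=C(Nc1cccc(-c2ccccc2)c1)C(Cl)Cl`: 8900 nM

Of these two, compound 2 gives the lower number, 8900 nM. Compound 3 `COC(=O)c1ccc(-c2cccc(NC(=O)C(Cl)Cl)c2)cc1` has methoxycarbonyl in place of hydrogen on an aromatic carbon. Among the compounds with values here, one measured step bears on this change: hydrogen in place of trifluoromethyl on an aromatic carbon, a 2.6-fold lower number from compound 1 to compound 2 (0.42 log units; beyond the scatter), a modest step beyond the scatter. Methoxycarbonyl itself has no measurement yet, so this is a loose guide. Read in reverse, it points to a modest rise in this assay. The expected step is a 1.7-fold higher number from compound 2 to compound 3 (0.23 log units; within the scatter). For compound 3 the estimated value is 15000 nM, with an expected range of 6000 nM to 35000 nM.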

Compound 3, half-maximal inhibitory concentration: > 50000 nM
Compound 3: only a limit was reported; the forecaster's own chance of this, stated with the estimate: 5%; middle value at least 3.3-fold (0.52 log units) from the limit.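

In this assay compound 3 gives > 50000 nM, which is a limit and not a number. Methoxycarbonyl at this position, para to a large group, gives an at least 5.6-fold higher number from compound 2 to compound 3 (0.74 log units; beyond the scatter), so the hydrogen of the unsubstituted compound is now favoured over two different groups there. It also goes further than trifluoromethyl, with an at least 2.1-fold higher number from compound 1 to compound 3 (0.32 log units; beyond the scatter).

From the compounds shown here alone, the true size of these steps remains open. So does whether a carboxylic acid, an amine or fluorine at this position would keep the number close to that of compound 2.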